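Thioether chain variation in a TRPV1 antagonist series

The source may report more compounds than this note shows. Statements on the series, on what has been measured and on what is new or still open speak of the compounds shown alone.

Measured in an assay on CHO-K1 cells for antagonist activity at transient receptor potential cation channel subfamily V member 1 (Homo sapiens), read by FLIPR; a lower number here means a stronger inhibitor, a higher number a weaker inhibitor:
compound 1 `CCCCCSc1nc(C(F)(F)F)ccc1CNC(=O)C(C)c1ccc(NS(C)(=O)=O)c(F)c1` gives 95.6 nM
compound 2 `CC(C(=O)NCc1ccc(C(F)(F)F)nc1SCCCN1CCCCC1)c1ccc(NS(C)(=O)=O)c(F)c1` gives 250 nM
compound 3 `CC1CCN(CCCSc2nc(C(F)(F)F)ccc2CNC(=O)C(C)c2ccc(NS(C)(=O)=O)c(F)c2)CC1` gives 217 nM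

Compound 3 stands second highest of the three numbers, separated from compound 2 only within the scatter; the step of a 2.3-fold higher number from compound 1 to compound 3 (0.36 log units; beyond the scatter) is beyond it, and a 2.6-fold higher number from compound 1 to compound 2 (0.42 log units; beyond the scatter) is of similar size. Compound 4 `COc1ccc(CSc2nc(C(F)(F)F)ccc2CNC(=O)C(C)c2ccc(NS(C)(=O)=O)c(F)c2)cc1` carries the change (4-methoxyphenyl in place of 2-(4-methylpiperidin-1-yl)ethyl on a saturated chain carbon bound to a sulfur). For the measured compounds named here, no measured step covers an aromatic group on this chain; the only bearing is that both amine-bearing chains gave modestly higher numbers than the plain alkyl chain of compound 1, and compound 4 removes the amine. A modest step downward is therefore expected, a 1.7-fold lower number from compound 3 to compound 4 (0.22 log units; within the scatter), with wide uncertainty. Compound 4 is estimated at 130 nM, within 45 nM to 400 nM.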

Compound 4, half-maximal inhibitory concentration: 279 nM
The estimate for compound 4 lay 2.1-fold (0.33 log units) below the measured number; the measured number falls inside the stated range.
By their numbers in this assay, from the lowest: compound 1; then compounds 3, 2 and 4 (each within the scatter of the next).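

In this assay the amine does not set these chains apart: going to the 4-methoxyphenyl group, which carries no amine, gives a 1.3-fold higher number from compound 3 to compound 4 (0.11 log units; within the scatter) and a 1.1-fold higher number from compound 2 to compound 4 (0.05 log units; within the scatter) on the same saturated chain carbon. Only the plain chain stands apart, with a 2.9-fold higher number from compound 1 to compound 4 (0.47 log units; beyond the scatter) as the change from butyl at this place. No evidence at hand accounts for this.

Open, from the compounds shown here alone, is whether a shorter or longer plain alkyl chain, or a benzyl without the methoxy, would sit with compound 1 or with the other three.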